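This account rests on a few compounds, and the source may have more. Where it says the series, first, only, none or still open, it means among the compounds named here.

In a functional assay on Ehrlich cells (Mus musculus) for cytotoxicity, read by LDH release, with a stated time of 48 h (a higher number here means a weaker inhibitor, a lower number a stronger inhibitor), compound 1 `COc1ccc(-c2csc(NC(=O)COc3ccc(C(=O)c4ccccc4)cc3C)n2)cc1` gives 28600 nM, and compound 2 `COc1ccc(-c2csc(NC(=O)COc3ccc(C(=O)c4cccc(Br)c4)cc3C)n2)cc1` gives 40600 nM. Among the compounds with values here, these are the only two numbers available and they lie within the usual scatter of each other, so compound 2 stands level with compound 1. Compound 3 `COc1ccc(-c2csc(NC(=O)COc3ccc(C(=O)c4cccc(F)c4)cc3C)n2)cc1` differs from compound 2 by fluoro in place of bromo on an aromatic carbon, which is fluoro in place of bromo on an aromatic carbon, meta to a large group. Within the data shown here, the one measured step that bears on this change is a 1.4-fold higher number from compound 1 to compound 2 (0.15 log units; within the scatter), where bromo took the place of hydrogen on that same aromatic carbon. Among the measured compounds shown here, with only this small step to go on, no clear shift is expected in this assay, and no direction can be expected beyond the scatter. The expected step is a 1.3-fold lower number from compound 2 to compound 3 (0.10 log units; within the scatter). Compound 3 is estimated at 32000 nM, with an expected range from 15000 nM to 68000 nM.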

Compound 3, half-maximal inhibitory concentration: 30900 nM
Compound 3: the middle estimate sits 1.0-fold (0.02 log units) above what was measured, and the stated range covers the measured number.
By their numbers in this assay, from the lowest: compounds 1, 3 and 2 (each within the scatter of the next).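

In this assay, going from 3-bromophenyl to 3-fluorophenyl gives a 1.3-fold lower number from compound 2 to compound 3 (0.12 log units; within the scatter), and fluoro in place of hydrogen on the same aromatic carbon gives a 1.1-fold higher number from compound 1 to compound 3 (0.03 log units; within the scatter). Together with the earlier bromo step, this places hydrogen, fluoro and bromo at this position level with one another, so the position has not yet responded to any of the three substituents, whether the atom is small or large. Nothing measured here offers a reason for this. The compounds shown leave open whether a group of another kind on this carbon, such as an amine, a carboxylic acid or a longer alkoxy chain, would move the number beyond the scatter. They also leave open whether a change elsewhere on the shared core would do so, since all three compounds differ only at this one carbon.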